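The source may hold more compounds than are shown below. What is called first, only, known or untested is meant among the compounds shown, and "the series" means these compounds.

Compound 1 `CCCCCCCCCCC(=O)NCC(C)(C)CC1=C(O)C(=O)c2ccccc2C1=O` and compound 2 `CCCCCCCCCCCC(=O)NCC(C)(C)CC1=C(O)C(=O)c2ccccc2C1=O` share one core, while compound 3 `CCCCCC(=O)OCC(C)(C)CC1=C(O)C(=O)c2ccccc2C1=O` is built on another; the difference between the two cores is not broken down here. In an ADME assay on Vero cells (Chlorocebus sabaeus) for cytotoxicity, read by reporter gene assay, with a stated time of 4 days (on this read-out lower numbers stand for stronger inhibition and higher numbers for weaker inhibition), compound 1 gives 14900 nM and compound 2 gives 13900 nM, so the change methyl in place of hydrogen on a saturated chain carbon, ten or more bonds along the chain from a carbonyl carbon made a step of a 1.1-fold lower number from compound 1 to compound 2 (0.03 log units; within the scatter). In this assay compound 3 gives 169000 nM, which stands well apart from both of the others. Compound 4 `CCCCCCC(=O)OCC(C)(C)CC1=C(O)C(=O)c2ccccc2C1=O` has not yet been measured; it differs from compound 3 by methyl in place of hydrogen on a saturated chain carbon, five bonds along the chain from a carbonyl carbon, the same kind of change as that between compound 1 and compound 2, though not at the same place on the chain. Because the earlier change gave only a 1.1-fold lower number from compound 1 to compound 2 (0.03 log units; within the scatter), the step expected here is about a 1.1-fold lower number from compound 3 to compound 4 (0.05 log units; within the scatter). Compound 4 is therefore estimated at 150000 nM in this assay, most likely between 75000 nM and 300000 nM.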

Compound 4, half-maximal inhibitory concentration: 99300 nM
For compound 4 the middle estimate is 1.5-fold (0.18 log units) above the measured one; the range from low to high includes it.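

In this assay the step on the core of compound 3 reads a 1.7-fold lower number from compound 3 to compound 4 (0.23 log units; within the scatter), and it sits close to the step for the same kind of change on the other core: the same change on two cores in this assay, a 1.1-fold lower number (0.03 log units; within the scatter) from compound 1 to compound 2 and a 1.7-fold lower number (0.23 log units; within the scatter) from compound 3 to compound 4, 1.6-fold (0.20 log units) apart, within the scatter of two such steps. Across these two cores, then, methyl in place of hydrogen on a saturated chain carbon gave no step beyond the scatter, and the two steps cannot be told apart. This rests on one pair per core, with the change at a different place on the chain in each, so it does not show that the change would carry over in the same way at other places or on other cores.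

The compounds shown leave open whether a chain ending in an amine or a carboxylic acid would give a similar reading in this assay. They also leave open how a longer chain on the core of compound 3 would read.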